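A Larger Amide Group in a Stable Set

This account rests on a few compounds, and the source may have more. Where it says the series, first, only, none or still open, it means among the compounds named here.

In an ADME assay on microsomes from liver (Mus musculus) for metabolic stability, read by LC-MS, using NADPH, with a stated time of 30 min, tested at 0.1 uM, in the presence of a further agent that is not named here (a lower number here means that less of the compound is left, a higher number that more of the compound is left), compound 1 `Nc1ccc(-c2cnc(N)c(-c3ccc(N)nc3)n2)cn1` gives > 90%, which is a limit and not a number. Compound 3 `Nc1ccc(-c2nc(-c3ccc(S(=O)(=O)C4CC4)cc3)cnc2N)cn1` gives > 90%, again a limit. Compound 2 `NC(=O)c1ccc(-c2cnc(N)c(-c3ccc(C(F)(F)F)cc3)n2)cc1` gives > 90%, also only a limit, so its exact place cannot be told. The whole picture so far is the limit of > 90% in this assay, at which 3 of the 3 values shown sit.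

Compound 4 `Nc1ncc(-c2ccc(C(=O)N3CCC(O)CC3)cc2)nc1-c1ccc(C(F)(F)F)cc1` differs from compound 2 at one place, where carbamoyl becomes (4-hydroxypiperidin-1-yl)carbonyl: 4-hydroxypiperidin-1-yl in place of amino on a carbonyl carbon. Among the compounds with values here, no measured step between compounds is available as a guide, so this is a cautious expectation of a moderate fall in this assay, though possibly none beyond the usual scatter. The expected move is a number at least 12 percentage points lower from compound 2 to compound 4 (beyond the scatter). For compound 4 the estimated value is 78%, with an expected range of 50% to 95%.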

Compound 4, percent of the compound remaining: > 90%
Compound 4: a limit, no number; the forecaster's own chance of this, stated with the estimate: 40%; middle value at least 12 percentage points away from the limit.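

In this assay, within the data shown here, compound 2 and compound 4 both stand at a limit and not at a number, so no step between them can be read. The compounds shown leave open which change, if any, would leave less of a compound remaining: the limit of > 90% in this assay, at which 4 of the 4 values shown sit.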